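Swapping an Imidazole for a Carbamoylpyridine on a Low-Solubility Core

A few compounds are considered here, and "the series" means these few. Any claim that something is new, unique, unknown or untested is made for them only; others in the source may bear on it.

Measured so far:
compound 1, `Cc1nccn1-c1cnc(NCc2c(F)ccc3c2CCO3)c2cn[nH]c(=O)c12`, 7000 nM
compound 2, `O=C1CCCN1c1cnc(NCc2c(F)ccc3c2CCO3)n2cnnc12`, 640000 nM

Among the measured compounds shown here, in a physicochemical assay for solubility, read by LC-MS, in phosphate buffer, with a stated time of 24 h, at pH 7.4 (a lower number here means a less soluble compound, a higher number a more soluble compound), compound 1 gives 7000 nM, the lower of the two numbers measured so far. Compound 2, `O=C1CCCN1c1cnc(NCc2c(F)ccc3c2CCO3)n2cnnc12`, reaches 640000 nM in this assay, a gap that lies beyond the usual scatter. Compound 2 differs from compound 1 in more than one place, so nothing can be said about any single change between them.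

Compound 3, `CNC(=O)c1ccc(-c2cnc(NCc3c(F)ccc4c3CCO4)c3cn[nH]c(=O)c23)c(C)n1`, is built from compound 1 by one change: 2-methyl-6-(methylcarbamoyl)pyridin-3-yl in place of 2-methyl-1H-imidazol-1-yl on an aromatic carbon. The incoming group is larger than the one it replaces and brings a hydrogen-bond donor where there was none. For the measured compounds named here, no measured pair shows this change, so there is no step to lean on. Given that compound 1 gives 7000 nM, the expectation for compound 3 is a number near that, with the step of a 1.4-fold lower number from compound 1 to compound 3 (0.15 log units; within the scatter) expected to stay inside the scatter or fall slightly. Compound 3 is estimated at 5000 nM, with a range from 1000 nM to 30000 nM.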

Compound 3, solubility: 19000 nM
The estimate for compound 3 lay 3.8-fold (0.58 log units) below the measured number; low and high end bracket the measured number.
By their numbers in this assay, from the lowest: compound 1; then compound 3; then compound 2.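

The step of a 2.7-fold higher number from compound 1 to compound 3 (0.43 log units; beyond the scatter) in this assay shows that this aromatic carbon of the shared core can carry a much larger group without the number falling. The number instead rises modestly, when 2-methyl-6-(methylcarbamoyl)pyridin-3-yl replaces 2-methyl-1H-imidazol-1-yl. Several things change together in this swap, as a five-membered ring gives way to a six-membered one and a hydrogen-bond donor enters, and nothing measured here explains the rise.

The compounds shown do not separate the contribution of the pyridine ring from that of the methylcarbamoyl group. They also leave open what a plain phenyl ring, or a pyridine carrying a carboxylic acid in place of the methylcarbamoyl group, would give on this same carbon.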